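Opening the cyclohexyl ring of compound 3 to a butyl chain

This account rests on a few compounds, and the source may have more. Where it says the series, first, only, none or still open, it means among the compounds named here.

Three compounds of the shared core carry an amine on the ether side and have been read in a physicochemical assay for solubility, read by nephelometry, measured as kinetic solubility, with a stated time of 30 min; a lower number here means a less soluble compound, a higher number a more soluble compound. Compound 1 `CC(C)(O)CNCCCOc1ccc([C@H]2CC[C@]3(CC2)OOC2(O3)C3CC4CC(C3)CC2C4)cc1` reaches the limit of the assay at > 100 ug/mL. Compound 2 `c1cc([C@H]2CC[C@]3(CC2)OOC2(O3)C3CC4CC(C3)CC2C4)ccc1OCCC1CCNCC1` also returns a limit, > 100 ug/mL. Within the data shown here, compound 3 `N[C@H]1CC[C@@H](Oc2ccc([C@H]3CC[C@]4(CC3)OOC3(O4)C4CC5CC(C4)CC3C5)cc2)CC1` is the only member with a number, giving 25 ug/mL in this assay. As far as the figures allow a comparison, compound 3 sits at the low end of the series, since the other two values are limits (the limit of > 100 ug/mL in this assay, at which 2 of the 3 values shown sit).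

The measured steps to compound 3 run in one direction: an at least 4.0-fold lower number from compound 1 to compound 3 (0.60 log units; beyond the scatter), and an at least 4.0-fold lower number from compound 2 to compound 3 (0.60 log units; beyond the scatter). The step between compound 1 and compound 2 cannot be read because both sit at the limit, a step that the two limits leave unreadable from compound 1 to compound 2.

Compound 4 `NCCCCOc1ccc([C@H]2CC[C@]3(CC2)OOC2(O3)C3CC4CC(C3)CC2C4)cc1` returns from compound 3 toward an open chain on the ether oxygen: 4-aminobutyl in place of 4-aminocyclohexyl on an oxygen on an aromatic ring. The two chain-bearing amines, compound 1 and compound 2, both reached the limit, and both steps from them to compound 3 were at least modest and downward, so the expectation for compound 4 is a rise from compound 3 of a 3.2-fold higher number from compound 3 to compound 4 (0.51 log units; beyond the scatter) in this assay, with a fair chance that only a limit is reported. Compound 4 is therefore estimated at 80 ug/mL, between 30 ug/mL and 160 ug/mL.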

Compound 4, solubility: 50 ug/mL
Compound 4: the middle estimate sits 1.6-fold (0.20 log units) above what was measured; the range from low to high includes it.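

In this assay, replacing the ring with the open chain on an oxygen on an aromatic ring gives no readable change at this position (a 2.0-fold higher number from compound 3 to compound 4 (0.30 log units; within the scatter)), although 4-aminobutyl has no ring and 4-aminocyclohexyl brings 2 defined stereocentres. Among these compounds, compound 4 therefore shows that a ring-free chain on this oxygen can give a number rather than a limit, yet its relation to the other two chain-bearing compounds remains unresolved, with an at least 2.0-fold lower number from compound 2 to compound 4 (0.30 log units; that floor lies within the scatter) and an at least 2.0-fold lower number from compound 1 to compound 4 (0.30 log units; that floor lies within the scatter) as the only readings. These floors are all that can be stated, and neither step can be sized further because compound 1 and compound 2 are limits: the limit of > 100 ug/mL in this assay, at which 2 of the 4 values shown sit.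

As far as these compounds go, it remains open whether a dimethylamino group in place of the primary amine at the end of the 4-aminobutyl chain, or a longer chain such as 6-aminohexyl, would move the number beyond the scatter. Also open, from the compounds shown here alone, is how a carboxylic acid or a hydroxyl group at the same chain end would read, which would test whether an amine is needed at this position at all.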